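A fluorophenyl amide moved around the ring

The source may report more compounds than this note shows. Statements on the series, on what has been measured and on what is new or still open speak of the compounds shown alone.

The three measured compounds share a core and differ only at the amide-type nitrogen. Compound 1 `O=C(Nc1cccc(F)c1)c1cncc(N2CC3CC(C2)N3)c1` gives 0.044 nM in an assay on membranes from Cerebral cortex for displacement of a labelled ligand from Neuronal acetylcholine receptor; alpha4/beta2 (Rattus norvegicus); on this read-out lower numbers stand for stronger inhibition and higher numbers for weaker inhibition. Compound 2 `O=C(c1cncc(N2CC3CC(C2)N3)c1)N1CCc2ccccc2C1` gives 0.031 nM in this assay. Compound 3 `O=C(Nc1ccccc1F)c1cncc(N2CC3CC(C2)N3)c1` gives 0.315 nM in this assay, which is the highest of the three numbers; its nearest neighbour is compound 1 and its furthest is compound 2. Within the data shown here, the one single-point step seen so far is the change from 3-fluorophenyl to 2-fluorophenyl on the amide-type nitrogen, which gave a 7.2-fold higher number from compound 1 to compound 3 (0.85 log units; beyond the scatter).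

Compound 4 `O=C(Nc1ccc(F)cc1)c1cncc(N2CC3CC(C2)N3)c1` is yet to be measured. It differs from compound 3 by 4-fluorophenyl in place of 2-fluorophenyl on an amide-type nitrogen, so its fluorophenyl group is neither that of compound 1 nor that of compound 3. Among the measured compounds shown here, the only step that bears on this change is the one from compound 1 to compound 3, and it shows that the 2-fluorophenyl group carries the higher number among the fluorophenyl amides. Compound 4 is therefore expected to sit closer to compound 1 than to compound 3, because compound 1 gave 0.044 nM with its fluorine elsewhere on the ring, giving an expected step of a 4.5-fold lower number from compound 3 to compound 4 (0.65 log units; beyond the scatter). The estimate for compound 4 in this assay is 0.07 nM, with a range from 0.02 nM to 0.3 nM.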

Compound 4, inhibition constant: 0.01 nM
For compound 4 the middle estimate is 7.0-fold (0.85 log units) above the measured one; the measured number lies below the stated range.
By their numbers in this assay, from the lowest: compound 4; then compounds 2 and 1 (each within the scatter of the next); then compound 3.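

Until now, the data showed only that 2-fluorophenyl gave a higher number than 3-fluorophenyl on the amide-type nitrogen. In this assay, 4-fluorophenyl goes lower than both, with a 32-fold lower number from compound 3 to compound 4 (1.50 log units; beyond the scatter) and a 4.4-fold lower number from compound 1 to compound 4 (0.64 log units; beyond the scatter) so that the three fluorophenyl amides separate into a clear order, each step beyond the scatter. The groups that leave and enter have the same atoms and the same counts, so this position tells apart groups that differ only in where the fluorine stands on the phenyl ring, though no measurement shown here explains that order.

The compounds shown leave open whether the order belongs to fluorine itself or would hold for other groups, and plain phenyl, 4-chlorophenyl or 4-methoxyphenyl on the same nitrogen would help to separate those two readings. Also open, going by these compounds, is how two fluorines on one ring would behave, as in 3,4-difluorophenyl, which combines the groups of compound 1 and compound 4.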